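A bromopyridinyl swap on the carbonyl carbon

A few compounds are considered here, and "the series" means these few. Any claim that something is new, unique, unknown or untested is made for them only; others in the source may bear on it.

In a functional assay on WM1361 cells (Homo sapiens) for antiproliferative activity, read by MTT assay, with a stated time of 48 h (a lower number here means a stronger inhibitor, a higher number a weaker inhibitor), compound 1 (`O=C(Nc1cc(-c2ccccc2)[nH]n1)c1ccc(Br)nc1`) gives 19400 nM and compound 2 (`O=C(Nc1cc(-c2ccc(Br)cc2)[nH]n1)c1cncc(Br)c1`) gives 20300 nM, so compound 2 stands level with compound 1 within the scatter. Compound 3 (`O=C(Nc1cc(-c2ccc(Br)cc2)[nH]n1)c1ccc(Br)nc1`) carries 6-bromopyridin-3-yl in place of 5-bromopyridin-3-yl on a carbonyl carbon. Going by the values given here, no measured step between the compounds covers this change, and no step beyond the scatter is expected in this assay, in either direction. The expected step is small, a 1.1-fold lower number from compound 2 to compound 3 (0.05 log units; within the scatter). For compound 3 the estimated value is 18000 nM, with an expected range of 8000 nM to 35000 nM.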

Compound 3, half-maximal inhibitory concentration: 20600 nM
The estimate for compound 3 lay 1.1-fold (0.06 log units) below the measured number; measured number inside the range.
By their numbers in this assay, from the lowest: compounds 1, 2 and 3 (each within the scatter of the next).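

In this assay, 6-bromopyridin-3-yl in place of 5-bromopyridin-3-yl on a carbonyl carbon gives a 1.0-fold higher number from compound 2 to compound 3 (0.01 log units; within the scatter) and so leaves the two compounds level, which shows that this position tolerates the swap of bromopyridinyl isomers in this series. Bromo in place of hydrogen on an aromatic carbon gives a 1.1-fold higher number from compound 1 to compound 3 (0.03 log units; within the scatter) and also leaves the two compounds level. No evidence bears on why either change leaves the values level. The compounds shown leave open whether an amine or a carboxylic acid in place of bromo on the pyridine ring would give a step beyond the scatter.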